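Removing a Methyl Group from Compound 3: Expected Cytotoxicity

The compounds below may be only part of what the source reports. "The series", "measured", "known", "first", "only" and "open" are said of these compounds alone.

Of the compounds shown here, three sharing a core have been tested in a functional assay on HPLF cells (Homo sapiens) for cytotoxicity; on this read-out higher numbers stand for lower toxicity in this test and lower numbers for higher toxicity in this test. Compound 1 `COc1cc(/C=C2\Cc3ccccc3/C(=C\c3ccc([N+](=O)[O-])cc3)C2=O)ccc1O` gives 21000 nM. Compound 2 `COc1cc(/C=C2\CCC/C(=C\c3ccc([N+](=O)[O-])cc3)C2=O)ccc1O`, which carries a different core, gives 171000 nM. For compound 3 `COc1ccc(/C=C2\Cc3ccccc3/C(=C\c3ccc([N+](=O)[O-])cc3)C2=O)cc1` the assay reports only a limit, > 400000 nM, so its true position is not known. Compound 4 `O=C1/C(=C/c2ccc(O)cc2)Cc2ccccc2/C1=C\c1ccc([N+](=O)[O-])cc1` has not yet been measured; it differs from compound 3 by hydrogen in place of methyl on an oxygen on an aromatic ring.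

Going by the values given here, the only measured step that bears on this change is an at least 19-fold higher number from compound 1 to compound 3 (1.27 log units; beyond the scatter). There, removing the hydroxy group (together with moving the methoxy) raised the number to the limit (the limit of > 400000 nM in this assay, at which 1 of the 3 values shown sits). Putting a hydroxy group back in compound 4, although without the methoxy group of compound 1, is therefore expected to pull the number down again, but it is not expected to fall all the way to the value of compound 1. For compound 4 the estimated value in this assay is 120000 nM, within a range from 25000 nM to 400000 nM, meaning an expected step of an at least 3.3-fold lower number from compound 3 to compound 4 (0.52 log units; beyond the scatter).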

Compound 4, half-maximal cytotoxic concentration: 75000 nM
Estimate against measurement, compound 4: 1.6-fold (0.20 log units) above; low and high end bracket the measured number.
By their numbers in this assay, from the lowest: compound 1; then compound 4; then compound 2. At a limit, above all of these: compound 3.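

Taken alone, the change from 4-methoxyphenyl to 4-hydroxyphenyl gives in this assay an at least 5.3-fold lower number from compound 3 to compound 4 (0.72 log units; beyond the scatter), so the hydroxy group lowers the number without any help from a second change on the ring. As far as these compounds go, the true size of this step remains unknown, since compound 3 gives only a limit: the limit of > 400000 nM in this assay, at which 1 of the 4 values shown sits. The methoxy group of compound 1 also counts on this read-out, since hydrogen in its place on the aromatic carbon gives a 3.6-fold higher number from compound 1 to compound 4 (0.55 log units; beyond the scatter).

From the compounds shown here alone, whether an amine in place of the hydroxy group would lower the number in the same way remains open. Going by these compounds, it is also open whether these two groups would have the same effects on the core of compound 2, which appears here with only one combination of them.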